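Carbamate to Trifluoromethylcyclopentyl Amide on the Shared Core

The source may hold more compounds than are shown below. What is called first, only, known or untested is meant among the compounds shown, and "the series" means these compounds.

Compound 1 `CC(C)OC(=O)N1CCC(O[C@H]2CC[C@H](Oc3ccc(S(C)(=O)=O)nc3)CC2)CC1` gives 13 nM in a functional assay on isolated protein for agonist activity at Glucose-dependent insulinotropic receptor (Homo sapiens), read by HTRF and cAMP accumulation; a higher number here means that more compound is needed for the effect, a lower number that less compound is needed.
Compound 2 `CC(C)(C)OC(=O)N1CCC(O[C@H]2CC[C@H](Oc3cnc(C#N)cn3)CC2)CC1` gives 8.3 nM in this assay.
Compound 3 `CC(C)OC(=O)N1CCC(O[C@H]2CC[C@H](Oc3cnc(S(C)(=O)=O)cn3)CC2)CC1` gives 13.7 nM in this assay.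

Compound 3 has the highest of the three numbers, yet the step is a 1.1-fold higher number from compound 1 to compound 3 (0.02 log units; within the scatter), and its gap to compound 2 is also within the scatter, so the three measured compounds cannot be ordered.

Compound 4 `CS(=O)(=O)c1cnc(O[C@H]2CC[C@H](OC3CCN(C(=O)C4(C(F)(F)F)CCCC4)CC3)CC2)cn1` differs from compound 3 in one place: a group of 9 heavy atoms (6 carbon, 3 fluorine; one five-membered non-aromatic ring of carbon only) in place of a group of 4 heavy atoms (3 carbon, 1 oxygen; no ring), on a carbonyl carbon. Among the compounds with values here, the only measured single step, a 1.1-fold higher number from compound 1 to compound 3 (0.02 log units; within the scatter), concerns the heteroaryl group on the other end of the shared core and says nothing about the carbonyl substituent. Compound 2 carries both a tert-butoxy group and a different heteroaryl group, and its value and that of compound 3 lie within the scatter of each other, which gives no guide to the carbonyl side alone. Nothing measured therefore bears directly on the step to compound 4.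

Within the data shown here, with no comparable step to lean on, compound 4 is expected to give a number near that of compound 3, so the estimated step is a 1.5-fold higher number from compound 3 to compound 4 (0.16 log units; within the scatter). The estimate for compound 4 in this assay is 20 nM, with a range from 5 nM to 80 nM.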

Compound 4, half-maximal effective concentration: 38.4 nM
Compound 4: middle estimate off by 1.9-fold (0.28 log units), on the low side; low and high end bracket the measured number.
By their numbers in this assay, from the lowest: compounds 2, 1 and 3 (each within the scatter of the next); then compound 4.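

In this assay, within the data shown here, the change on the carbonyl carbon gives a 2.8-fold higher number from compound 3 to compound 4 (0.45 log units; beyond the scatter), a modest step but one beyond the scatter, whereas the one earlier single change, on the heteroaryl end of the shared core, stayed within it. This position is therefore the first in the series where a single change separates two compounds, and the amide compound 4, at 38.4 nM, still responds in the nanomolar range without the isopropoxy group and its hydrogen-bond acceptor. No measurement offered here accounts for the step, so the change can be described but not explained.

This one step cannot show which part of the entering group goes with the higher number, the trifluoromethyl group, the five-membered carbon ring, or the replacement of the carbamate by an amide; a plain cyclopentyl or a tert-butyl group on the same carbonyl carbon would begin to separate them. Going by these compounds, it is also open whether the step would be of similar size with the nitrile-bearing heteroaryl group of compound 2 or the 6-(methylsulfonyl)pyridin-3-yl group of compound 1 on the other end of the shared core.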